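Sulfoxide Analogue Series: Cytotoxicity in Cultured Cells

The compounds below may be only part of what the source reports. "The series", "measured", "known", "first", "only" and "open" are said of these compounds alone.

Compound 1 `COc1cc2nc(SCC(=O)Nc3ccc(F)cc3)nc(Nc3c(C)cc(/C=C/C#N)cc3C)c2cc1OC` and compound 2 `COc1cc2nc(SCC(=O)Nc3ccc(C(F)(F)F)cc3)nc(Nc3c(C)cc(/C=C/C#N)cc3C)c2cc1OC` share one core, while compound 3 `COc1cc2nc([S+]([O-])CC(=O)Nc3ccc(F)cc3)nc(Nc3c(C)cc(/C=C/C#N)cc3C)c2cc1OC` and compound 4 `COc1cc2nc([S+]([O-])CC(=O)Nc3ccc(C(F)(F)F)cc3)nc(Nc3c(C)cc(/C=C/C#N)cc3C)c2cc1OC` share another; the difference between the two cores is not broken down here. In an ADME assay on MT4 cells (Homo sapiens) for cytotoxicity, read by MTT assay, with a stated time of 5 days (on this read-out lower numbers stand for higher toxicity in this test and higher numbers for lower toxicity in this test), compound 1 gives >= 150000 nM, which is a limit of the assay and not a number. In this assay compound 2 gives > 211000 nM, likewise a limit. The change between them, (trifluoromethyl in place of fluoro on an aromatic carbon), therefore yields a step that the two limits leave unreadable from compound 1 to compound 2, unreadable because the limit of > 211000 nM in this assay, at which 1 of the 3 values shown sits, and the limit of >= 150000 nM in this assay, at which 1 of the 3 values shown sits, bound both values. In this assay, going by the values given here, compound 3 gives 27400 nM, the only plain number among the three measured compounds. Compound 4 arises from compound 3 by trifluoromethyl in place of fluoro on an aromatic carbon, the same change as from compound 1 to compound 2, since the surroundings of the altered site read identically in both pairs. With the earlier step unreadable, the expectation for compound 4 rests on compound 3 alone and its value of 27400 nM: a step of a 1.1-fold higher number from compound 3 to compound 4 (0.04 log units; within the scatter) is expected, with wide uncertainty. Compound 4 is thus estimated at 30000 nM, with a range from 10000 nM to 100000 nM.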

Compound 4, half-maximal cytotoxic concentration: 52200 nM
Estimate against measurement, compound 4: 1.7-fold (0.24 log units) below; measured number inside the range.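

In this assay, trifluoromethyl in place of fluoro on the core of compound 3 gives a 1.9-fold higher number from compound 3 to compound 4 (0.28 log units; within the scatter), so on this core the change produces no difference that can be told apart from repeat-to-repeat variation. The same change on the core of compound 1 cannot be read, since the values of compound 1 and compound 2 are both limits of the assay and not numbers. This leaves a single readable case: it shows how the change behaves on one core, but it does not show that the change carries over from one core to the other, since a comparison needs a readable step on each.

The compounds shown leave open how a chloro group, a methoxy group, an amine or a carboxylic acid in the same place would read in this assay. They also leave open whether any such group would behave alike on both cores.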